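Naphthalen-1-yl replacing 2,4-dihydroxyphenyl: working notes

This account rests on a few compounds, and the source may have more. Where it says the series, first, only, none or still open, it means among the compounds named here.

Values in a functional assay on HCT-116 cells (Homo sapiens) for inhibition, read by MTT assay, with a stated time of 48 h; on this read-out lower numbers stand for stronger inhibition and higher numbers for weaker inhibition
- compound 1 `COc1cc(-c2cc(-c3cccc(O)c3)nc(-c3ccccc3)n2)cc(OC)c1OC` gives 20400 nM
- compound 2 `COc1cc(-c2cc(-c3ccc(O)cc3O)nc(-c3ccccc3)n2)cc(OC)c1OC` gives 5890 nM
- compound 3 `COc1cc(-c2cc(-c3cccc4ccccc34)nc(-c3ccccc3)n2)cc(OC)c1OC` is not yet measured

Of the two measured compounds, compound 2 has the lower number, at 5890 nM. The next change is naphthalen-1-yl in place of 2,4-dihydroxyphenyl on an aromatic carbon. For the measured compounds named here, the only measured step at this place is a 3.5-fold lower number from compound 1 to compound 2 (0.54 log units; beyond the scatter), a modest one. Going by the values given here, no measured compound carries naphthalen-1-yl, so that step is only a loose guide. A modest rise is expected, an estimated 2.0-fold higher number from compound 2 to compound 3 (0.31 log units; beyond the scatter) in this assay. For compound 3 the expected value is 12000 nM, with an estimated range of 4000 nM to 40000 nM.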

Compound 3, half-maximal inhibitory concentration: 4930 nM
Estimate against measurement, compound 3: 2.4-fold (0.39 log units) above; the range from low to high includes it.
By their numbers in this assay, from the lowest: compounds 3 and 2 (each within the scatter of the next); then compound 1.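

In this assay naphthalen-1-yl at this place gives a 1.2-fold lower number from compound 2 to compound 3 (0.08 log units; within the scatter) and so cannot be told apart from 2,4-dihydroxyphenyl, although it has 0 hydrogen-bond donors and 0 hydrogen-bond acceptors. Against 3-hydroxyphenyl, the same change gives a 4.1-fold lower number from compound 1 to compound 3 (0.62 log units; beyond the scatter), so among these compounds a hydroxyl group at this place is not required for the lower numbers. Nothing on hand explains this result. Going by these compounds, whether an amine or a carboxylic acid at this place would keep, raise or lower the number remains open.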